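Aryl sulfonyl variation on the shared core

The source may report more compounds than this note shows. Statements on the series, on what has been measured and on what is new or still open speak of the compounds shown alone.

Measured so far in a functional assay on CHO cells for antagonist activity at 5-hydroxytryptamine receptor 6 (Homo sapiens), read by FLIPR; a higher number here means a weaker inhibitor, a lower number a stronger inhibitor:
- compound 1 `CN1CCC(N(C)C(=O)C2CN(S(=O)(=O)c3cccc4ccccc34)c3ccccc32)CC1`: 31.6 nM
- compound 2 `CN1CCC(N(C)C(=O)C2CN(S(=O)(=O)c3ccc(C(F)(F)F)cc3)c3ccccc32)CC1`: 25.1 nM

Both compounds share one core and differ only in the aryl group on the sulfonyl sulfur. Within the data shown here, the single step between them, a 1.3-fold lower number from compound 1 to compound 2 (0.10 log units; within the scatter), stays within the scatter, so the two numbers cannot be ordered; compound 2 merely carries the lower of the two values, with compound 1 nearest to it.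

Compound 3 `COc1ccc(S(=O)(=O)N2CC(C(=O)N(C)C3CCN(C)CC3)c3ccccc32)c(C)c1C` is not yet measured. It differs from compound 2 in one place: 4-methoxy-2,3-dimethylphenyl in place of 4-(trifluoromethyl)phenyl on a sulfonyl sulfur. Among the measured compounds shown here, the only step that bears on this change is the earlier aryl swap on the same sulfonyl sulfur, a 1.3-fold lower number from compound 1 to compound 2 (0.10 log units; within the scatter), which was small. That step offers no sign that this position is sensitive to the aryl group, but the two aryl groups seen so far give only a narrow view, and the entering group brings a hydrogen-bond acceptor and two methyl groups not seen before.

Compound 3 is therefore expected to give about 32 nM in this assay, within a range of 10 nM to 100 nM. The step implied by this estimate, a 1.3-fold higher number from compound 2 to compound 3 (0.11 log units; within the scatter), is expected to lie within the scatter, with no direction claimed.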

Compound 3, inhibition constant: 100 nM
Compound 3: middle estimate off by 3.1-fold (0.49 log units), on the low side; low and high end bracket the measured number.
By their numbers in this assay, from the lowest: compounds 2 and 1 (each within the scatter of the next); then compound 3.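

In this assay the aryl group on the sulfonyl sulfur now makes a readable difference: the change to 4-methoxy-2,3-dimethylphenyl gives a 4.0-fold higher number from compound 2 to compound 3 (0.60 log units; beyond the scatter) and a 3.2-fold higher number from compound 1 to compound 3 (0.50 log units; beyond the scatter) and both steps lie beyond the scatter, whereas the earlier swap between the other two aryl groups did not. Heavy-atom count does not separate 4-(trifluoromethyl)phenyl from 4-methoxy-2,3-dimethylphenyl, as the two groups carry the same number, so this step comes with fluorine leaving, oxygen and more carbon entering, and a hydrogen-bond acceptor appearing on a group that had none. Nothing measured here ties the higher number to any one of these features.

On these data alone, the methoxy group and the two methyl groups enter together, so the share of each in the step stays open, and a phenyl carrying only the methoxy group or only the two methyl groups would separate them. Also open, as far as these compounds go, is how an aryl group carrying an amine or a carboxylic acid, or a longer alkyl chain in place of the aryl group on the sulfonyl sulfur, would read in this assay on the shared core.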